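Adding a bromo to the indole side of the shared core

The source may report more compounds than this note shows. Statements on the series, on what has been measured and on what is new or still open speak of the compounds shown alone.

Compound 3 `N#C/C(=C\C=C(/Cl)c1ccc(Br)cc1)C(=O)c1c[nH]c2ccccc12` stands highest of three in a functional assay for inhibition, with a stated time of 5 min, tested at 1 mM (a lower number here means less inhibition, a higher number more inhibition at the concentration tested (going by the name of the read-out)), where compound 3 gives 65.5%. For the measured compounds named here, compound 1 `COc1ccc(/C(Cl)=C/C=C(\C#N)C(=O)c2c[nH]c3ccc(Br)cc23)cc1` gives 62.2%, within the scatter of compound 3, while compound 2 `COc1ccc2[nH]cc(C(=O)/C(C#N)=C/C=C(\Cl)c3ccc(Br)cc3)c2c1` gives 54.5%; the step of a number 11 percentage points higher from compound 2 to compound 3 (beyond the scatter) is the only one that separates two compounds beyond the scatter. Compound 4 `N#C/C(=C\C=C(/Cl)c1ccc(Br)cc1)C(=O)c1c[nH]c2ccc(Br)cc12` differs from compound 3 by bromo in place of hydrogen on an aromatic carbon. Going by the values given here, no measured step swaps hydrogen for bromo at this place, so the expectation rests on compound 1, which also carries bromo there and sits within the scatter of compound 3. The step of a number 2.5 percentage points lower from compound 3 to compound 4 (within the scatter) is therefore expected to stay within the scatter, and compound 4 is estimated to give 63%, between 50% and 76%.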

Compound 4, a percentage reported as inhibition, at one concentration (the size of the read-out at that concentration, not a potency): 83.6%
Estimate against measurement, compound 4: 20.6 percentage points below; measured number above the stated range.
By their numbers in this assay, from the lowest: compounds 2, 1 and 3 (each within the scatter of the next, the first and the last beyond it); then compound 4.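

In this assay, bromo in place of hydrogen at this place gives a number 18.1 percentage points higher from compound 3 to compound 4 (beyond the scatter), so the group here clearly changes the read-out. Bromo in place of methoxy at the same place gives a number 29.1 percentage points higher from compound 2 to compound 4 (beyond the scatter), and the same swap at a second place gives a number 21.4 percentage points higher from compound 1 to compound 4 (beyond the scatter), which leaves compound 4 highest of the four. Nothing available explains these rises. From the compounds shown here alone, whether the gain is special to bromo remains open, as fluoro, chloro or an amine at this place could give a different number. A reading at one concentration also leaves potency open.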